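A few compounds are considered here, and "the series" means these few. Any claim that something is new, unique, unknown or untested is made for them only; others in the source may bear on it.

The measured compounds and their values:

Compound 1, `CCOC(=O)CN(c1nc(Cl)nc2c1ncn2C1CCCCO1)C1CC1`, gives 13%.
Compound 2, `O=C(O)CN(c1nc(Cl)nc2c1ncn2C1CCCCO1)C1CC1`, gives 8.22%.
Compound 3, `CC[C@H](C)[C@H](NC(=O)CN(c1nc(Cl)nc2c1ncn2C1CCCCO1)C1CC1)C(=O)OCc1ccccc1`, gives 22.6%.

All three values come from a functional assay on the whole organism with Mus musculus as the target, with a stated time of 90 min, at a dose of 25 umol/kg by the oral route; on this read-out lower numbers stand for a weaker effect and higher numbers for a stronger effect at the one dose given. Compound 3 holds the highest of the three numbers. Its nearest neighbour is compound 1, a difference that lies within the scatter, so the two cannot be ordered; compound 2 stands furthest off, and that gap lies beyond the scatter.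

Compound 4, `CC(C)[C@H](NC(=O)CN(c1nc(Cl)nc2c1ncn2C1CCCCO1)C1CC1)C(=O)OCc1ccccc1`, differs from compound 3 by hydrogen in place of methyl on a saturated chain carbon, three bonds along the chain from an amide-type nitrogen and a carbonyl carbon; cut one bond further out, the same difference reads sec-butyl to isopropyl. Within the data shown here, the only measured step, a number 4.8 percentage points lower from compound 1 to compound 2 (within the scatter), concerns the other end of the molecule, where the ester is changed, and it was within the scatter. Among the measured compounds shown here, no measured step touches the side chain where compound 4 differs, so there is nothing in the data to argue for a shift in either direction. The expected step is estimated as a number 2.6 percentage points lower from compound 3 to compound 4 (within the scatter), none beyond the scatter. Compound 4 is therefore estimated at about 20%, with a likely range from 8% to 32%.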

Compound 4, a percentage reported as activity, at one dose (the size of the read-out at that dose, not a potency): 30.1%
Compound 4: middle estimate off by 10.1 percentage points, on the low side, within the range that was stated.
By their numbers in this assay, from the lowest: compounds 2, 1, 3 and 4 (each within the scatter of the next, the first and the last beyond it).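

In this assay, trimming sec-butyl to isopropyl, which puts hydrogen in place of methyl on a saturated chain carbon, three bonds along the chain from an amide-type nitrogen and a carbonyl carbon, gives a number 7.5 percentage points higher from compound 3 to compound 4 (within the scatter), so the read-out does not separate the two compounds. Among these compounds, this is the first measured step at this side chain, since the earlier step, a number 4.8 percentage points lower from compound 1 to compound 2 (within the scatter), concerned the ethyl on the ester oxygen; it shows that, at this one oral dose, removing a single methyl here leaves the read-out within the usual scatter. No available evidence bears on this result.

What the compounds shown leave open is whether a side chain cut back further to ethyl or methyl, or one carrying an amine or a carboxylic acid at this carbon, would move the value beyond the scatter. Also open, as far as these compounds go, is whether the benzyl ester shared by these two compounds could give way to an ethyl ester or a free carboxylic acid with the isopropyl group in place.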